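Swapping an acid for its ethyl ester

The source may hold more compounds than are shown below. What is called first, only, known or untested is meant among the compounds shown, and "the series" means these compounds.

Measured in a functional assay on A549 cells (Homo sapiens) for cytotoxicity, read by MTT assay; a lower number here means a stronger inhibitor, a higher number a weaker inhibitor:
- Compound 1 `CCOC(=O)C(C)Oc1cc(O)c2c(=O)c(O)c(-c3ccc(OC)cc3)oc2c1CC=C(C)C` gives 26500 nM
- Compound 2 `COc1ccc(-c2oc3c(CC=C(C)C)c(OCC(=O)O)cc(O)c3c(=O)c2O)cc1` gives 16700 nM

Among the measured compounds shown here, compound 2 holds the lower of only two numbers, but the gap is small: the measured step is a 1.6-fold lower number from compound 1 to compound 2 (0.20 log units; within the scatter). The two compounds therefore cannot be told apart in this assay.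

Compound 3 `CCOC(=O)COc1cc(O)c2c(=O)c(O)c(-c3ccc(OC)cc3)oc2c1CC=C(C)C` keeps the core of compound 2 and changes one small part of it: ethyl in place of hydrogen on an oxygen next to a carbonyl group. Cut one bond further out, this turns carboxymethyl into (ethoxycarbonyl)methyl.

For the measured compounds named here, only one measured step bears on this change. Compound 1 already carries an ethoxycarbonyl group, within its 1-(ethoxycarbonyl)ethyl chain, where compound 2 has carboxymethyl. That comparison therefore contains the same carboxy to ethoxycarbonyl difference, although the two chains also differ in another way. Since a 1.6-fold lower number from compound 1 to compound 2 (0.20 log units; within the scatter) stayed small, no shift beyond the scatter is expected in this assay, and a single step is thin evidence. At most a slight drift towards the number of compound 1 seems likely, so the expected change is a 1.3-fold higher number from compound 2 to compound 3 (0.10 log units; within the scatter). For compound 3 the estimated value is 21000 nM, with an expected range of 10000 nM to 44000 nM.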

Compound 3, half-maximal inhibitory concentration: 41600 nM
Compound 3: middle estimate off by 2.0-fold (0.30 log units), on the low side; the range from low to high includes it.
By their numbers in this assay, from the lowest: compounds 2, 1 and 3 (each within the scatter of the next, the first and the last beyond it).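

Among the compounds shown here, compound 3 isolates this change for the first time: with the rest of the molecule held fixed, ethyl in place of hydrogen on an oxygen next to a carbonyl group gives a 2.5-fold higher number from compound 2 to compound 3 (0.40 log units; beyond the scatter) in this assay. For the compounds shown here, the earlier step from compound 1 to compound 2 mixed the same carboxy to ethoxycarbonyl difference with a second change in the chain, and it stayed within the scatter, so only this new pair shows a modest penalty for the ethyl ester compared with the free acid. The second difference can now be read alone as well: hydrogen in place of methyl on a saturated chain carbon bound to a carbonyl carbon and an oxygen on an aromatic ring gives a 1.6-fold higher number from compound 1 to compound 3 (0.20 log units; within the scatter) and so cannot be told apart from no change in this assay. Nothing presented here offers an explanation for the step between the acid and the ester.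

The compounds shown leave open whether a longer chain on this oxygen, such as butyl, would raise the number further. They also leave open whether an amide, with an amine joined to the same carbonyl, would sit closer to the acid or to the ester.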